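Swapping the pyridine substituent on the thiazole core

The compounds below may be only part of what the source reports. "The series", "measured", "known", "first", "only" and "open" are said of these compounds alone.

Compound 1 `O=C(O)Cc1sc(C(c2ccc(F)cc2)c2ccc(F)cc2)nc1-c1ccccc1` gives 16 nM in an in vitro assay on HEK385-7 cells for displacement of a labelled ligand from prostaglandin D2 receptor 2 (Homo sapiens); on this read-out higher numbers stand for weaker inhibition and lower numbers for stronger inhibition. Compound 2 `Nc1cc(-c2nc(C(c3ccc(F)cc3)c3ccc(F)cc3)sc2CC(=O)O)cc(F)n1` gives 220 nM, and compound 3 `O=C(O)Cc1sc(C(c2ccc(F)cc2)c2ccc(F)cc2)nc1-c1ccnc(N2CCCC2)c1` gives 230 nM. Compound 3 therefore carries the highest number of the three measured; compound 2 sits within the scatter of it, while compound 1 lies well beyond it, since the change a 14-fold higher number from compound 1 to compound 3 (1.16 log units; beyond the scatter).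

Compound 4 `Cc1cc(-c2nc(C(c3ccc(F)cc3)c3ccc(F)cc3)sc2CC(=O)O)cnc1N` differs from compound 3 by 6-amino-5-methylpyridin-3-yl in place of 2-(pyrrolidin-1-yl)pyridin-4-yl on an aromatic carbon. Among the measured compounds shown here, two measured steps bear on this: a 14-fold higher number from compound 1 to compound 2 (1.14 log units; beyond the scatter) and a 14-fold higher number from compound 1 to compound 3 (1.16 log units; beyond the scatter), both large and of the same size, and a 1.0-fold higher number from compound 2 to compound 3 (0.02 log units; within the scatter). Both aminopyridinyl and pyrrolidinylpyridinyl groups on this position thus gave numbers close to one another. Another pyridinyl group bearing an amino group and a methyl group is expected to behave much like compound 2 and compound 3, so no step beyond the scatter is expected: a 1.2-fold lower number from compound 3 to compound 4 (0.06 log units; within the scatter). Compound 4 is therefore estimated at 200 nM, within a range of 60 nM to 700 nM.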

Compound 4, half-maximal inhibitory concentration: 880 nM
For compound 4 the middle estimate is 4.4-fold (0.64 log units) below the measured one, and the stated range ends below it.
By their numbers in this assay, from the lowest: compound 1; then compounds 2 and 3 (each within the scatter of the next); then compound 4.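

The match between compounds 2 and 3 does not hold for every amino-bearing pyridinyl group at this position: in this assay the new group separates from both (a 3.8-fold higher number from compound 3 to compound 4 (0.58 log units; beyond the scatter); a 4.0-fold higher number from compound 2 to compound 4 (0.60 log units; beyond the scatter)). It also gives the largest step seen so far on replacing phenyl (a 55-fold higher number from compound 1 to compound 4 (1.74 log units; beyond the scatter)), so this site distinguishes among pyridinyl groups and does not treat them as one class. Nothing measured here gives a reason for this shift.

Compound 4 differs from compound 2 both in how the pyridine is attached and in carrying methyl where compound 2 carries fluoro, so the compounds shown cannot separate these two changes. From the compounds shown here alone, a 2-amino-6-methylpyridin-4-yl group or a 6-aminopyridin-3-yl group without the methyl would pull them apart, and how either behaves remains open.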